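This account rests on a few compounds, and the source may have more. Where it says the series, first, only, none or still open, it means among the compounds named here.

The series here is a set of acylguanidines built on one shared core. Compound 1 `Cc1nc(N)sc1CCCNC(=N)NC(=O)C[C@@H](C)c1ccccc1` carries the 1-phenylethyl group with its stereocentre drawn R, and in an in vitro functional assay on Sf9 cells for agonist activity at histamine H2 receptor (Homo sapiens), read by GTPgammaS binding (a lower number here means that less compound is needed, a higher number that more compound is needed for the effect), compound 1 gives 53.7 nM. Compound 2 `Cc1nc(N)sc1CCCNC(=N)NC(=O)C[C@H](C)C1CCCCC1` has 1-cyclohexylethyl in its place, and in this assay compound 2 gives 28.8 nM. Compound 3 `Cc1nc(N)sc1CCCNC(=N)NC(=O)CC(C)c1ccccc1` has the same atoms and bonds as compound 1 but its stereocentre is drawn without a configuration; in this assay compound 3 gives 50.1 nM. Among the three numbers compound 3 stands second highest, nearest to compound 1 and furthest from compound 2, both within the scatter.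

The three steps are all small: a 1.9-fold lower number from compound 1 to compound 2 (0.27 log units; within the scatter), a 1.1-fold lower number from compound 1 to compound 3 (0.03 log units; within the scatter), and a 1.7-fold higher number from compound 2 to compound 3 (0.24 log units; within the scatter).

Compound 4 `Cc1nc(N)sc1CCCNC(=N)NC(=O)C[C@H](C)c1ccccc1` is the next compound. (the two compounds have the same atoms and bonds; at least one stereo element is drawn with a configuration in one of them and without one in the other: 1 of 2 stereo elements differ; a stereocentre at a saturated chain carbon is drawn without a configuration in compound 3 and S in compound 4). Among the compounds with values here, the step that bears on it is the one between compound 1 and compound 3, where the fact that one of compounds 1 and 3 is drawn with a defined configuration and the other without, at the place where they differ marks the same kind of difference, and that step stayed within the scatter. The account therefore expects no step beyond the scatter in this assay from compound 3 to compound 4, that is a 1.0-fold lower number from compound 3 to compound 4 (0.00 log units; within the scatter). For compound 4 the estimate is 50 nM, with a range from 22 nM to 115 nM.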

Compound 4, half-maximal effective concentration: 28.2 nM
For compound 4 the middle estimate is 1.8-fold (0.25 log units) above the measured one, and the stated range covers the measured number.
By their numbers in this assay, from the lowest: compounds 4, 2, 3 and 1 (each within the scatter of the next).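

Within the data shown here, with compound 4, the stereocentre at the saturated chain carbon now appears drawn both R and S, where the earlier compounds offered only R against an undrawn centre. In this assay, the direct comparison of the two drawn forms gives a 1.9-fold lower number from compound 1 to compound 4 (0.28 log units; within the scatter), and the comparison of the undrawn form with the S form gives a 1.8-fold lower number from compound 3 to compound 4 (0.25 log units; within the scatter), so no configuration at this position separates from another beyond the scatter. The exchange of ring groups also holds up with the S-drawn phenyl compound, at a 1.0-fold lower number from compound 2 to compound 4 (0.01 log units; within the scatter), so phenyl and cyclohexyl at this carbon stay within the scatter of each other in all three comparisons between them.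

On these data alone, these small steps cannot say whether the configuration has any real effect here, and the cyclohexyl group appears in one drawn configuration only, so its behaviour in the opposite form remains unknown. As far as these compounds go, whether the same holds with an ethyl group in place of the methyl at the stereocentre, or with a hydroxyl group on the phenyl ring, also stays open.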